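Dropping one trifluoromethyl from the urea of compound 2

The compounds below may be only part of what the source reports. "The series", "measured", "known", "first", "only" and "open" are said of these compounds alone.

Of the compounds shown here, three sharing one core have been measured in a functional assay on MDA-MB-231 cells (Homo sapiens) for inhibition, read by sulforhodamine B assay, with a stated time of 48 h; a lower number here means a stronger inhibitor of growth, a higher number a weaker inhibitor of growth. Compound 1 `COc1cc(-c2nn(-c3cccc(NC(=O)c4cccc(C(F)(F)F)c4)c3)cc2-c2ccncc2)ccc1Cl` gives 1240 nM, compound 3 `COc1cc(-c2nn(-c3cccc(NC(=O)c4ccccc4)c3)cc2-c2ccncc2)ccc1Cl` gives 1170 nM, and compound 2 `O=C(Nc1cccc(-n2cc(-c3ccncc3)c(-c3ccc(Cl)c(O)c3)n2)c1)Nc1cc(C(F)(F)F)cc(C(F)(F)F)c1` gives 739 nM. Compound 2 has the lowest of the three numbers, yet its gaps to compound 3 and to compound 1 both lie within the usual scatter, so no order among them can be claimed.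

Compound 4 `O=C(Nc1cccc(-n2cc(-c3ccncc3)c(-c3ccc(Cl)c(O)c3)n2)c1)Nc1cccc(C(F)(F)F)c1` is not yet measured. It differs from compound 2 in one place: hydrogen in place of trifluoromethyl on an aromatic carbon. Among the measured compounds shown here, the one measured step of this kind, a 1.1-fold lower number from compound 1 to compound 3 (0.03 log units; within the scatter), removed a trifluoromethyl from an aromatic carbon in the amide branch of the core and changed the number by no more than the scatter allows. On that basis the step of a 1.0-fold higher number from compound 2 to compound 4 (0.01 log units; within the scatter) is expected to be small, with no direction that can be told apart from scatter. Compound 4 is therefore estimated at 750 nM, within a range of 350 nM to 1600 nM.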

Compound 4, concentration for 50% growth inhibition: 3590 nM
Compound 4: the middle estimate sits 4.8-fold (0.68 log units) below what was measured; the measured number lies above the stated range.
By their numbers in this assay, from the lowest: compounds 2, 3 and 1 (each within the scatter of the next); then compound 4.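

Taking one trifluoromethyl off the aromatic ring of the urea of compound 2 is not a neutral change in this assay, giving a 4.9-fold higher number from compound 2 to compound 4 (0.69 log units; beyond the scatter). The second trifluoromethyl on this ring therefore matters here, even though compound 1, whose amide branch carries only one, showed no step beyond the scatter when it lost that group. The same swap of hydrogen for trifluoromethyl thus does not carry a single size from one core to the other: the same change on two cores in this assay, a 1.1-fold lower number (0.03 log units; within the scatter) from compound 1 to compound 3 and a 4.9-fold higher number (0.69 log units; beyond the scatter) from compound 2 to compound 4, 5.1-fold (0.71 log units) apart, beyond the scatter of two such steps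

The two cores differ in more than one place, with a urea or an amide and with a hydroxyl or a methoxy group, so these compounds cannot tell which difference separates the two steps. Also open, going by these compounds, is whether a nitrile or a methyl group at this place on compound 4 would bring the number back towards that of compound 2.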